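This account rests on a few compounds, and the source may have more. Where it says the series, first, only, none or still open, it means among the compounds named here.

Measured so far in an in vitro assay on Sf21 cells for inhibition of high affinity 3',5'-cyclic-AMP phosphodiesterase 7A (Homo sapiens), read by scintillation proximity assay, with a stated time of 30 min; a higher number here means a weaker inhibitor, a lower number a stronger inhibitor: compound 1 `N#Cc1ccc(NC(=O)c2cn(Cc3c(F)cccc3F)c3ccc(=O)[nH]c3c2=O)cc1` gives 96 nM; compound 2 `N#Cc1cccc(NC(=O)c2cn(Cc3c(F)cccc3F)c3ccc(=O)[nH]c3c2=O)c1` gives 1070 nM; compound 3 `O=C(NCc1ccncc1)c1ccc(NC(=O)c2cn(Cc3c(F)cccc3F)c3ccc(=O)[nH]c3c2=O)cc1` gives 20 nM.

Compound 3 stands lowest of these three numbers in this assay, separated from compound 1 by a 4.8-fold lower number from compound 1 to compound 3 (0.68 log units; beyond the scatter) and from compound 2 by a still wider gap. Compound 4 `CSc1ccc(NC(=O)c2cn(Cc3c(F)cccc3F)c3ccc(=O)[nH]c3c2=O)cc1` has not yet been measured; it differs from compound 3 by methylsulfanyl in place of ((pyridin-4-yl)methyl)carbamoyl on an aromatic carbon. Among the measured compounds shown here, the one step that bears on this change is a 4.8-fold lower number from compound 1 to compound 3 (0.68 log units; beyond the scatter), which went in the opposite direction, from a small group on that carbon to the large one. The step of an 11-fold higher number from compound 1 to compound 2 (1.05 log units; beyond the scatter) concerns a different position and offers no guidance here. Replacing the large group with methylsulfanyl is therefore expected to raise the number, roughly a 7.5-fold higher number from compound 3 to compound 4 (0.88 log units; beyond the scatter). Compound 4 is estimated at 150 nM, within a range of 50 nM to 500 nM.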

Compound 4, half-maximal inhibitory concentration: 86 nM
For compound 4 the middle estimate is 1.7-fold (0.24 log units) above the measured one; the measured number falls inside the stated range.
By their numbers in this assay, from the lowest: compound 3; then compounds 4 and 1 (each within the scatter of the next); then compound 2.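

In this assay, methylsulfanyl in place of cyano on this aromatic carbon gives no readable difference (a 1.1-fold lower number from compound 1 to compound 4 (0.05 log units; within the scatter)), so the two groups cannot be told apart here. Against a second group, ((pyridin-4-yl)methyl)carbamoyl again gives the lower number (a 4.3-fold higher number from compound 3 to compound 4 (0.63 log units; beyond the scatter)), and 4-(methylsulfanyl)phenyl, like 4-cyanophenyl, stands well apart from 3-cyanophenyl (a 12-fold lower number from compound 2 to compound 4 (1.09 log units; beyond the scatter)). Nothing given here accounts for these steps. As far as these compounds go, whether a primary amine, a carboxylic acid or a longer chain on this carbon would give a number like that of ((pyridin-4-yl)methyl)carbamoyl remains open.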